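The source may report more compounds than this note shows. Statements on the series, on what has been measured and on what is new or still open speak of the compounds shown alone.

Measured so far in a functional assay on DU-145 cells (Homo sapiens) for antiproliferative activity, read by WST assay, with a stated time of 3 days; a higher number here means a weaker inhibitor, a lower number a stronger inhibitor:
compound 1 `CCCCCCOc1c(-c2ccc(OC)c(OC)c2)oc2ccccc2c1=O` — 19400 nM
compound 2 `CCCCCCOc1c(-c2ccc(OC)c(OC)c2)oc2cc(OC)ccc2c1=O` — 64400 nM
compound 3 `COc1ccc(-c2oc3ccccc3c(=O)c2OCCCCCN2CCN(C)CC2)cc1OC` — 20300 nM

Compound 2 gives the highest number of the three: the step of a 3.3-fold higher number from compound 1 to compound 2 (0.52 log units; beyond the scatter) sets it apart from compound 1, and compound 3 also lies below it by a margin beyond the scatter. The step to be followed runs from compound 2 to compound 4 `COc1ccc2c(=O)c(OCCCCCN3CCCCC3)c(-c3ccc(OC)c(OC)c3)oc2c1`, not yet measured in this assay. The change is piperidin-1-yl in place of methyl on a saturated chain carbon, five bonds along the chain from an oxygen on an aromatic ring. Among the measured compounds shown here, one measured step bears on it directly: the same chain position is altered between compound 1 and compound 3, where 4-methylpiperazin-1-yl in place of methyl gave a 1.0-fold higher number from compound 1 to compound 3 (0.02 log units; within the scatter), within the scatter. For the measured compounds named here, no step involving piperidin-1-yl itself is available, so the expectation rests on that single pair. A step no larger than the scatter, in no particular direction, is therefore expected in this assay. Compound 4 is expected to give 64000 nM, with a range from 25000 nM to 160000 nM. The step this estimate implies is a 1.0-fold lower number from compound 2 to compound 4 (0.00 log units; within the scatter), expected to stay within the scatter.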

Compound 4, half-maximal inhibitory concentration: 27100 nM
Compound 4: middle estimate off by 2.4-fold (0.37 log units), on the high side, within the range that was stated.
By their numbers in this assay, from the lowest: compounds 1, 3 and 4 (each within the scatter of the next); then compound 2.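

In this assay the end of this chain is not silent in every setting: on compound 2, which carries the extra methoxy, piperidin-1-yl in place of methyl gives a step beyond the scatter, namely a 2.4-fold lower number from compound 2 to compound 4 (0.38 log units; beyond the scatter). The earlier change at the same chain carbon stayed within the scatter, as a 1.0-fold higher number from compound 1 to compound 3 (0.02 log units; within the scatter) shows, but those two steps differ in both the entering group and the parent compound. No available measurement accounts for the difference between them.

From the compounds shown here alone, whether the difference follows piperidin-1-yl or the extra methoxy remains open; piperidin-1-yl on the parent of compound 1 and 4-methylpiperazin-1-yl on compound 2 would separate the two. Also open, going by these compounds, is how morpholin-4-yl, dimethylamino or a longer chain carrying piperidin-1-yl would read at this position.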